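This account rests on a few compounds, and the source may have more. Where it says the series, first, only, none or still open, it means among the compounds named here.

Going by the values given here, compound 2, `C/C=C/C=C/C(=O)OCC`, gives 1.84 in a physicochemical assay for lipophilicity (a lower number here means a more polar compound, a higher number a more lipophilic compound), the higher of the two numbers measured so far. Among the compounds with values here, its only neighbour, compound 1, `C/C=C/C=C/C(=O)N(C)C`, gives 1.1 in this assay; the one measured step between them, a number 0.74 log units higher from compound 1 to compound 2 (beyond the scatter), arose from ethoxy in place of dimethylamino on a carbonyl carbon. Compound 3, `C=CCOC(=O)/C=C/C=C/C`, awaits measurement in this assay. It differs from compound 2 as follows: vinyl in place of methyl on a saturated chain carbon bound to an oxygen next to a carbonyl group. Within the data shown here, no measured step bears directly on this kind of change, since the step from compound 1 to compound 2 exchanged the group on the carbonyl carbon itself rather than lengthening the chain on the oxygen next to the carbonyl group. With two carbon atoms entering for one leaving, and one double bond added outside aromatic rings, compound 3 is expected to rise by a number 0.41 log units higher from compound 2 to compound 3 (beyond the scatter) in this assay, a step beyond the scatter but smaller than the measured one. Compound 3 is therefore estimated to give 2.25 in this assay, within a range from 1.95 to 2.55.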

Compound 3, partition coefficient: 2.24
For compound 3 the middle estimate is 0.01 log units above the measured one; low and high end bracket the measured number.
By their numbers in this assay, from the lowest: compound 1; then compound 2; then compound 3.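

In this assay, going by these compounds alone, the step of a number 0.40 log units higher from compound 2 to compound 3 (beyond the scatter) is the first measured reading for a change on a saturated chain carbon bound to an oxygen next to a carbonyl group. The earlier step of a number 0.74 log units higher from compound 1 to compound 2 (beyond the scatter) exchanged the group on the carbonyl carbon itself and left this chain untested, whereas the new step shows that vinyl in place of methyl at this place, which reads as ethyl to allyl one bond further out, moves the number beyond the scatter while the rest of the molecule stays the same. Nothing given here accounts for the size or direction of this step.

This single step joins an additional carbon and a double bond in one change, so it cannot separate what each contributes, and a saturated propyl chain at the same place would be the comparison that parts the two. Also open, going by these compounds, is how a chain carrying an amine or a carboxylic acid would read at this place in this assay and whether the step would recur on a different core.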